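The source may report more compounds than this note shows. Statements on the series, on what has been measured and on what is new or still open speak of the compounds shown alone.

Measured so far in a functional assay on CCRF-CEM cells for antagonist activity at C-X-C chemokine receptor type 4 (Homo sapiens), read by calcium flux, with stated times of 25 min and 90 s; a higher number here means a weaker inhibitor, a lower number a stronger inhibitor:
compound 1, `CN(C[C@H]1Cc2c(cccc2N2CCN(Cc3ccccn3)CC2)CN1)[C@H]1CCCc2cccnc21`, compound 1 gives 4.47 nM
compound 2, `c1cnc2c(c1)CCC[C@@H]2N(CC1CCCCC1)C[C@H]1Cc2c(cccc2N2CCNCC2)CN1`, compound 2 gives 715 nM

Of the two numbers, compound 2 holds the higher one. Going by the values given here, its only neighbour is compound 1, whose number is lower by a gap that lies well beyond the usual scatter; the two structures differ in more than one place, so that gap cannot be assigned to any single change.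

Compound 3 is `CN(C[C@H]1Cc2c(cccc2N2CCNCC2)CN1)[C@H]1CCCc2cccnc21`. It differs from compound 2 in one place only: hydrogen in place of cyclohexyl on a saturated chain carbon bound to an amine nitrogen. Among the compounds with values here, no measured pair differs at just this place, so the step has no direct precedent. Compound 1 likewise bears methyl rather than cyclohexylmethyl here and stands far below compound 2, but it differs elsewhere as well, so it guides the estimate only loosely. A fall in this assay beyond the scatter is expected; the expected step is a 14-fold lower number from compound 2 to compound 3 (1.16 log units; beyond the scatter). Compound 3 is estimated at 50 nM, with a likely range from 8 nM to 300 nM.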

Compound 3, half-maximal inhibitory concentration: 6.08 nM
Compound 3: middle estimate off by 8.2-fold (0.92 log units), on the high side; measured number outside the range, below it.
By their numbers in this assay, from the lowest: compounds 1 and 3 (each within the scatter of the next); then compound 2.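

In this assay, going by these compounds alone, hydrogen in place of cyclohexyl on a saturated chain carbon bound to an amine nitrogen, which reads one bond further out as cyclohexylmethyl to methyl, gives a 120-fold lower number from compound 2 to compound 3 (2.07 log units; beyond the scatter) in the first single-place reading at this position, so the read-out depends strongly on this group. The other single-place reading, hydrogen in place of (pyridin-2-yl)methyl on an amine nitrogen in a ring, gives a 1.4-fold higher number from compound 1 to compound 3 (0.13 log units; within the scatter), so that change shows no effect that can be read in this assay while methyl stands on the chain. No accompanying data address the reason for either step.

Only two end points are shown at the chain position, methyl and cyclohexylmethyl, so it remains open whether the number climbs gradually or abruptly through groups such as ethyl, isobutyl or benzyl, and whether a chain ending in an amine or a carboxylic acid behaves like either end point. On these data alone, it also remains open whether (pyridin-2-yl)methyl on the ring nitrogen would still make no readable difference with cyclohexylmethyl on the chain.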